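A few compounds are considered here, and "the series" means these few. Any claim that something is new, unique, unknown or untested is made for them only; others in the source may bear on it.

Measured so far in an assay on isolated protein for inhibition of Polyunsaturated fatty acid 5-lipoxygenase (Rattus norvegicus); on this read-out higher numbers stand for weaker inhibition and lower numbers for stronger inhibition:
Compound 1 `CCOCC1CN(c2ccccc2)NC1=O` gives 280 nM.
Compound 2 `COCCOCC1CN(c2ccccc2)NC1=O` gives 520 nM.
Compound 3 `COCCC1CN(c2ccccc2)NC1=O` gives 480 nM; 10300 nM; 350 nM (3 entries), three separate entries.

Compound 2 stands at the higher of the two single numbers, compound 1 being nearest; the step of a 1.9-fold higher number from compound 1 to compound 2 (0.27 log units; within the scatter) is within the scatter, so the two cannot be ordered. Compound 3 has no single number; its entries the several entries of compound 3 in this assay, 480 nM; 10300 nM; 350 nM (3 entries) spread widely, two of them close to compounds 1 and 2 and one far higher.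

Compound 4 `CCOCCC1CN(c2ccccc2)NC1=O` differs from compound 2 by ethoxymethyl in place of 2-methoxyethoxy on a saturated chain carbon bound to a saturated ring carbon. Its side chain resembles those of compound 1 and compound 3, and both of those sit near compound 2 on the numbers available. Among the compounds with values here, the only step measured in one place, a 1.9-fold higher number from compound 1 to compound 2 (0.27 log units; within the scatter), is within the scatter, and the wide spread of compound 3 the several entries of compound 3 in this assay, 480 nM; 10300 nM; 350 nM (3 entries) counsels caution rather than a direction. No step beyond the scatter is expected in this assay. Expected, therefore, is a step of a 1.3-fold lower number from compound 2 to compound 4 (0.11 log units; within the scatter). Compound 4 is expected near 400 nM, within a range of 150 nM to 1500 nM.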

Compound 4, half-maximal inhibitory concentration: 150 nM
Compound 4: middle estimate off by 2.7-fold (0.43 log units), on the high side, within the range that was stated.
By their numbers in this assay, from the lowest: compounds 4, 1 and 2 (each within the scatter of the next, the first and the last beyond it).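

In this assay, within the data shown here, ethoxymethyl in place of 2-methoxyethoxy on a saturated chain carbon bound to a saturated ring carbon gives a 3.5-fold lower number from compound 2 to compound 4 (0.54 log units; beyond the scatter), the first step to lie beyond the scatter. Ethoxymethyl in place of ethoxy at that same place gives a 1.9-fold lower number from compound 1 to compound 4 (0.27 log units; within the scatter), so compound 1 and compound 4 cannot be ordered, any more than compound 1 and compound 2, and only compound 2 and compound 4 separate. The two groups in the readable step differ in both heavy atoms and hydrogen-bond acceptors, and these compounds do not show which of the two differences matters, or whether either does.

Among these compounds, compound 3 has no single number, so no step to it can be read: the several entries of compound 3 in this assay, 480 nM; 10300 nM; 350 nM (3 entries) Also open is how an amine, a carboxylic acid or a longer all-carbon chain on a saturated chain carbon bound to a saturated ring carbon would compare with ethoxymethyl in this assay's read-out.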